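A few compounds are considered here, and "the series" means these few. Any claim that something is new, unique, unknown or untested is made for them only; others in the source may bear on it.

Measured so far in a functional assay on HEK293 cells for agonist activity at D(4) dopamine receptor (Homo sapiens), read by FLIPR; on this read-out higher numbers stand for an effect only at larger amounts of compound and lower numbers for an effect already at smaller amounts:
Compound 1, `C=Cc1cccc(C(=O)NCN2CCC(c3cccc[n+]3[O-])CC2)c1`: compound 1 gives 68 nM
Compound 2, `N#Cc1cccc(C(=O)NCN2CCC(c3cccc[n+]3[O-])CC2)c1`: compound 2 gives 840 nM
Compound 3, `Cc1cc(C)cc(C(=O)NCN2CCC(c3cccc[n+]3[O-])CC2)c1`: compound 3 gives 90 nM

Compound 3 stands second highest of the three numbers. Its nearest neighbour is compound 1, with a 1.3-fold higher number from compound 1 to compound 3 (0.12 log units; within the scatter); its furthest is compound 2, with a 9.3-fold lower number from compound 2 to compound 3 (0.97 log units; beyond the scatter).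

The next compound in the series is compound 4, `O=C(NCN1CCC(c2cccc[n+]2[O-])CC1)c1cc(Cl)cc(Cl)c1`. The change from compound 3 is 3,5-dichlorophenyl in place of 3,5-dimethylphenyl on a carbonyl carbon.

Going by the values given here, no measured pair exchanges 3,5-dimethylphenyl for 3,5-dichlorophenyl, so nothing bears directly on this step. What the measured steps show is that the group on the carbonyl carbon can matter a great deal or hardly at all: a 12-fold higher number from compound 1 to compound 2 (1.09 log units; beyond the scatter) is a large move, whereas a 1.3-fold higher number from compound 1 to compound 3 (0.12 log units; within the scatter) lies within the scatter. Among the compounds with values here, both rings in the present change carry the same pattern of two substituents on the phenyl, and the closest precedent, compound 1 against compound 3, shows two such rings giving numbers within the scatter of each other.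

The step of a 1.1-fold higher number from compound 3 to compound 4 (0.05 log units; within the scatter) is therefore expected to stay within the scatter, in no particular direction, with a wide range allowed for the lack of a direct precedent. For compound 4 the estimate in this assay is 100 nM, between 35 nM and 300 nM.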

Compound 4, half-maximal effective concentration: 45 nM
Estimate against measurement, compound 4: 2.2-fold (0.35 log units) above; the measured number falls inside the stated range.
By their numbers in this assay, from the lowest: compounds 4, 1 and 3 (each within the scatter of the next); then compound 2.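

In this assay, the change from two methyl groups to two chlorine atoms on the ring at the carbonyl carbon stays within the scatter (a 2.0-fold lower number from compound 3 to compound 4 (0.30 log units; within the scatter)), and the 3,5-dichlorophenyl ring also lies within the scatter of the 3-vinylphenyl ring (a 1.5-fold lower number from compound 1 to compound 4 (0.18 log units; within the scatter)). Compound 2 now stands apart from three compounds rather than two (a 19-fold lower number from compound 2 to compound 4 (1.27 log units; beyond the scatter)), so among the rings shown at this position, only the 3-cyanophenyl ring gives a number beyond the scatter of the others. No measurement at hand explains either this separation or the closeness of the other three rings.

The compounds shown leave open whether the higher number of compound 2 belongs to the nitrile specifically or would also appear with other groups on the ring, such as a carboxylic acid, an amine or a methoxy group. They also do not show how much of the result depends on substitution at all, since a plain phenyl ring on the carbonyl carbon is absent from this set.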